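A few compounds are considered here, and "the series" means these few. Any claim that something is new, unique, unknown or untested is made for them only; others in the source may bear on it.

Compound 1 `CN(C)CCn1c(N)c(-c2nc3ccccc3[nH]2)c2nc(C#N)c(C#N)nc21` gives 8880 nM
Compound 2 `CCCCn1c(N)c(-c2nc3ccccc3[nH]2)c2nc(C#N)c(C#N)nc21` gives > 50000 nM as a limit

Both readings come from a functional assay on HeLa cells (Homo sapiens) for antiproliferative activity, read by MTT assay, with a stated time of 48 h (a higher number here means a weaker inhibitor, a lower number a stronger inhibitor), and compound 2 stands there with > 50000 nM as a limit of the assay and not a number. Compound 3 `N#Cc1nc2c(-c3nc4ccccc4[nH]3)c(N)n(CCCN3CCCCC3)c2nc1C#N` differs from compound 2 by one change (piperidin-1-yl in place of methyl on a saturated chain carbon, three bonds along the chain from an aromatic nitrogen) with piperidin-1-yl in place of methyl on a saturated chain carbon, three bonds along the chain from an aromatic nitrogen.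

Among the compounds with values here, one measured step bears on this. It runs an at least 5.6-fold higher number from compound 1 to compound 2 (0.75 log units; beyond the scatter) and came with ethyl in place of dimethylamino on the chain. Compound 3 again carries a nitrogen-bearing group on its chain, as compound 1 does with 8880 nM in this assay so a step of similar size toward a stronger inhibitor is expected, though this rests on a single pair. The estimated step is an at least 7.1-fold lower number from compound 2 to compound 3 (0.85 log units; beyond the scatter) in that direction. For compound 3 the expected value is 7000 nM with an estimated range from 1500 nM to 30000 nM as the upper end.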

Compound 3, half-maximal inhibitory concentration: 6680 nM
Compound 3: middle estimate off by 1.0-fold (0.02 log units), on the high side; the measured number falls inside the stated range.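

In this assay, within the data shown here, 3-(piperidin-1-yl)propyl in place of butyl on the aromatic nitrogen gives an at least 7.4-fold lower number from compound 2 to compound 3 (0.87 log units; beyond the scatter), so a second chain carrying an amine, different from the one in compound 1, also stands clear of the butyl compound. Compound 2 gives a limit of the assay and not a number, so this step has only a lower bound: the limit of > 50000 nM in this assay, at which 1 of the 3 values shown sits. With (piperidin-1-yl)methyl in place of dimethylamino, the result is a 1.3-fold lower number from compound 1 to compound 3 (0.12 log units; within the scatter), which lies within the scatter, so the two amine chains cannot be told apart here despite the added ring and the different end group.

As far as these compounds go, whether a morpholine ring or a hydroxyl group at the chain end would serve as well stays open. So does the effect of a longer chain carrying the same piperidine.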